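Swapping a methoxyphenyl amide for an imidazole amide

The source may hold more compounds than are shown below. What is called first, only, known or untested is meant among the compounds shown, and "the series" means these compounds.

Compound 1 `COc1ccc(-c2cnc(NC(=O)c3cccc(OC)c3)n2C)cc1` and compound 2 `Cn1c(-c2ccccc2)cnc1NC(=O)c1cccc(Cl)c1` share a core and differ in the ring that carries the amide. In a toxicity assay on THP-1 cells (Homo sapiens) for inhibition (on this read-out higher numbers stand for lower toxicity in this test and lower numbers for higher toxicity in this test), compound 1 gives > 100000 nM, which is a limit of the test rather than a number. In this assay compound 2 gives > 50000 nM, again a limit. Compound 1 therefore stands only at the limit of > 100000 nM in this assay, at which 1 of the 2 values shown sits, without a number of its own. Compound 3 `COc1ccc(-c2cnc(NC(=O)c3cnc[nH]3)n2C)cc1` is not yet measured and differs from compound 1 by 1H-imidazol-5-yl in place of 3-methoxyphenyl on a carbonyl carbon. Within the data shown here, with no measured step to draw on, nothing beyond the usual scatter is expected. For compound 3 the estimated value is 100000 nM, within 40000 nM to 250000 nM. The expected step is a number no higher from compound 1 to compound 3 (the limit leaves the size open).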

Compound 3, half-maximal cytotoxic concentration: > 100000 nM
Compound 3 ended at the assay's limit (the forecaster's own chance of this, stated with the estimate: 75%); the middle value sits exactly at the limit.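

Among these compounds, compound 1 and compound 3 both end at a limit of the test, so no step between them can be read: the limit of > 100000 nM in this assay, at which 2 of the 3 values shown sit. Going by these compounds, the concentration at which either compound would reach its half-maximal toxicity in this assay remains open.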